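This account rests on a few compounds, and the source may have more. Where it says the series, first, only, none or still open, it means among the compounds named here.

Measured compounds in an assay on CHO cells for displacement of a labelled ligand from adenosine receptor A1 (Homo sapiens), read by scintillation counting, with a stated time of 120 min, tested at 10 uM; a higher number here means more inhibition at the concentration tested (going by the name of the read-out), a lower number less inhibition:
compound 1 `Nc1scc(CN2CCN(c3ccc(OC(F)(F)F)cc3)CC2)c1C(=O)c1ccc(Cl)cc1` gives 0%.
compound 2 `Nc1scc(CN2CCN(c3cccc(F)c3)CC2)c1C(=O)c1ccc(Cl)cc1` gives 1%.
compound 3 `Nc1scc(CN2CCN(c3c(F)cccc3F)CC2)c1C(=O)c1ccc(Cl)cc1` gives 1%.

Compound 3 stands level with compound 2 at the digits shown, and the two together hold the highest of the three numbers, yet its distance to compound 1 is within the scatter, so none of the three compounds separates from the others. The steps recorded so far are small: a number 1 percentage points higher from compound 1 to compound 2 (within the scatter), a number 1 percentage points higher from compound 1 to compound 3 (within the scatter) and no change at the digits printed from compound 2 to compound 3 (within the scatter). Every exchange of the aryl group on the ring amine nitrogen tried in this assay has left the read-out essentially at zero.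

Compound 4 `Nc1scc(CN2CCN(c3ccc(F)c(Cl)c3)CC2)c1C(=O)c1ccc(Cl)cc1` is the next member of the series. It differs from compound 3 in one place: 3-chloro-4-fluorophenyl in place of 2,6-difluorophenyl on an amine nitrogen in a ring. The three measured steps all bear on this change, since each of them likewise exchanges the aryl group on that nitrogen, and each stayed within the scatter. Nothing in the series points to a direction of change, so the read-out for compound 4 is expected to stay near zero, with a step of no change at the digits printed from compound 3 to compound 4 (within the scatter) from compound 3 expected to lie within the scatter. The estimate for compound 4 in this assay is 1%, within a range from 0% to 8%.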

Compound 4, a percentage reported as inhibition, at one concentration (the size of the read-out at that concentration, not a potency): 0%
Beside the measured number, compound 4's estimate is 1 percentage points above it; the measured number falls inside the stated range.
By their numbers in this assay, from the lowest: compounds 1, 4, 2 and 3 (each within the scatter of the next).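

The 3-chloro-4-fluorophenyl group brings a chlorine into the aryl group on the amine nitrogen in a ring, a halogen that compounds 1 to 3 do not carry there, and the read-out in this assay still does not move (a number 1 percentage points lower from compound 3 to compound 4 (within the scatter)) (a number 1 percentage points lower from compound 2 to compound 4 (within the scatter)) (no change at the digits printed from compound 1 to compound 4 (within the scatter)). The flat result at this position now covers four aryl groups: a single fluorine, two fluorines, a trifluoromethoxy group, and a chlorine with a fluorine, and none of compounds 1 to 4 separates from the others. No available evidence accounts for this flat read-out.

All four compounds keep the rest of the shared core unchanged and carry a substituted phenyl group on this nitrogen, so the data say nothing about how changes elsewhere in the core affect the read-out. From the compounds shown here alone, whether a pyridine ring or a benzyl group on that nitrogen, or a carboxylic acid or an amine on the phenyl ring, would lift the read-out in this assay clear of the scatter remains open.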